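Replacing an aryl-ether tail with a fused bicyclic tail

This account rests on a few compounds, and the source may have more. Where it says the series, first, only, none or still open, it means among the compounds named here.

Compound 1 `COc1ccc(CCCN2CCC(C(O)CC(c3ccccc3)c3ccccc3)CC2)cc1` gives 1500 nM in a functional assay on cells (T-cell line, Homo sapiens) for inhibition; on this read-out higher numbers stand for weaker inhibition and lower numbers for stronger inhibition.
Compound 2 `COc1ccc(CCCN2CCC(=CCC(c3ccccc3)c3ccccc3)CC2)cc1` gives 400 nM in this assay.
Compound 3 `COc1ccccc1CCCN1CCC(COC(c2ccccc2)c2ccccc2)CC1` gives 2400 nM in this assay.

Among the three measured values, compound 3 shows the highest number. The gap to compound 1 is within the usual scatter, so the two cannot be ranked against each other; the gap to compound 2 lies beyond the scatter. Compound 4 `c1ccc(C(OCC2CCN(CC3CCc4ccccc4C3)CC2)c2ccccc2)cc1` differs from compound 3 in one place: 1,2,3,4-tetrahydronaphthalen-2-yl in place of 2-(2-methoxyphenyl)ethyl on a saturated chain carbon bound to an amine nitrogen in a ring. Among the measured compounds shown here, no measured pair shows what such an exchange does, so the direction is uncertain; a step of modest size, not clearly beyond the scatter, is expected in this assay. Compound 4 is therefore estimated at 2000 nM, with a range from 700 nM to 6000 nM, meaning an expected step of a 1.2-fold lower number from compound 3 to compound 4 (0.08 log units; within the scatter).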

Compound 4, half-maximal inhibitory concentration: 5600 nM
Compound 4: the middle estimate sits 2.8-fold (0.45 log units) below what was measured; the measured number falls inside the stated range.
By their numbers in this assay, from the lowest: compound 2; then compounds 1 and 3 (each within the scatter of the next); then compound 4.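

Putting 1,2,3,4-tetrahydronaphthalen-2-yl in place of 2-(2-methoxyphenyl)ethyl gives a 2.3-fold higher number from compound 3 to compound 4 (0.37 log units; beyond the scatter) in this assay and so weaker inhibition. Among the compounds shown here, this is the first sign that inhibition responds to what sits at this place on the amine side of the molecule, even when the exchange keeps the same number of heavy atoms. Nothing available explains this step.

The exchange removes the methoxy oxygen and adds a second ring at once, so the two changes cannot be told apart. A plain 2-phenylethyl group at this place would separate them.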